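Bromo-methoxy for fluoro on a bis-styryl diketone core

The source may report more compounds than this note shows. Statements on the series, on what has been measured and on what is new or still open speak of the compounds shown alone.

Compound 1 `COc1ccc(/C=C/C(=O)C(=Cc2ccc(O)c(F)c2)C(=O)/C=C/c2ccc(OC)cc2OC)c(OC)c1` gives 5450 nM in a functional assay on MCF7 cells (Homo sapiens) for antiproliferative activity, read by sulforhodamine B assay, with a stated time of 48 h; a lower number here means a stronger inhibitor, a higher number a weaker inhibitor. Compound 2 `COc1ccc(/C=C/C(=O)C(=Cc2cc(Br)c(O)c(OC)c2)C(=O)/C=C/c2ccc(OC)cc2OC)c(OC)c1` carries 3-bromo-4-hydroxy-5-methoxyphenyl in place of 3-fluoro-4-hydroxyphenyl on a double-bonded chain carbon bound to a double-bonded chain carbon and gives 2600 nM, so the step is a 2.1-fold lower number from compound 1 to compound 2 (0.32 log units; beyond the scatter). Compound 3 `COc1cc(OC)c(/C=C/C(=O)C(=Cc2ccc(O)c(F)c2)C(=O)/C=C/c2c(OC)cc(OC)cc2OC)c(OC)c1` has a different core; the difference between the two cores is not broken down here. In this assay compound 3 gives 3180 nM, which sits within the scatter of both compound 2 and compound 1. Compound 4 `COc1cc(OC)c(/C=C/C(=O)C(=Cc2cc(Br)c(O)c(OC)c2)C(=O)/C=C/c2c(OC)cc(OC)cc2OC)c(OC)c1` is not yet measured; relative to compound 3 it carries 3-bromo-4-hydroxy-5-methoxyphenyl in place of 3-fluoro-4-hydroxyphenyl on a double-bonded chain carbon bound to a double-bonded chain carbon, the same change as from compound 1 to compound 2, at the same place. Within the data shown here, compound 4 is expected to show a 2.1-fold lower number from compound 3 to compound 4 (0.33 log units; beyond the scatter), resting on the single measured step of a 2.1-fold lower number from compound 1 to compound 2 (0.32 log units; beyond the scatter) on the other core. The estimate for compound 4 is 1500 nM, with a range from 700 nM to 3300 nM.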

Compound 4, half-maximal inhibitory concentration: 1460 nM
Beside the measured number, compound 4's estimate is 1.0-fold (0.01 log units) above it, within the range that was stated.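

In this assay, 3-bromo-4-hydroxy-5-methoxyphenyl in place of 3-fluoro-4-hydroxyphenyl gives a 2.2-fold lower number from compound 3 to compound 4 (0.34 log units; beyond the scatter). The change carries over with the same size on the two cores: the same change on two cores in this assay, a 2.1-fold lower number (0.32 log units; beyond the scatter) from compound 1 to compound 2 and a 2.2-fold lower number (0.34 log units; beyond the scatter) from compound 3 to compound 4, 1.0-fold (0.02 log units) apart, within the scatter of two such steps. This shows transfer between these two cores only, on two pairs in one cell line, and it does not separate the contribution of the bromine from that of the methoxy, which enter together.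

Still open, as far as these compounds go, is whether the bromine or the methoxy alone would give the same step on either core. Also open, from the compounds shown here alone, is whether the step would hold on a ring carrying an amine or a carboxylic acid, or on a third core.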